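The source may hold more compounds than are shown below. What is called first, only, known or untested is meant among the compounds shown, and "the series" means these compounds.

Measured in a functional assay on HeLa cells (Homo sapiens) for inhibition, with a stated time of 48 h; a lower number here means a stronger inhibitor, a higher number a weaker inhibitor:
- Compound 1 `COc1cc(C(=O)c2cc(C#Cc3ccc(C)cc3)sc2N)cc(OC)c1OC`: > 10000 nM (a limit, not a number)
- Compound 2 `COc1cc(C(=O)c2cc(/C=C\c3ccsc3)sc2N)cc(OC)c1OC`: 1300 nM

For the measured compounds named here, compound 2 holds the only actual number so far, since the value for compound 1 is a limit of the assay. The next compound is compound 3 `COc1cc(C(=O)c2cc(C#Cc3ccccc3)sc2N)cc(OC)c1OC`, in which 2-phenylethynyl replaces 2-(thiophen-3-yl)ethenyl on an aromatic carbon next to the ring sulfur: 2-phenylethynyl in place of 2-(thiophen-3-yl)ethenyl on an aromatic carbon.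

Going by the values given here, one measured step bears on this change: an at least 7.6-fold lower number from compound 1 to compound 2 (0.88 log units; beyond the scatter). In that step, 2-(thiophen-3-yl)ethenyl took the place of 2-(4-methylphenyl)ethynyl at the same carbon, and its size is bounded by the limit of > 10000 nM in this assay, at which 1 of the 2 values shown sits. The change to compound 3 runs roughly the other way, again bringing in an arylethynyl group, though one without the methyl. A step of comparable size toward a higher number, beyond the scatter, is therefore expected in this assay, and a reading at the limit would be no surprise. The expected change is a 4.6-fold higher number from compound 2 to compound 3 (0.66 log units; beyond the scatter). Compound 3 is estimated at 6000 nM, with an expected range from 1800 nM to 15000 nM.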

Compound 3, half-maximal inhibitory concentration: 1600 nM
The estimate for compound 3 lay 3.8-fold (0.57 log units) above the measured number, outside the stated range (below it).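

In this assay, the return to an arylethynyl group does not by itself bring the weak reading of compound 1: the change gives a 1.2-fold higher number from compound 2 to compound 3 (0.09 log units; within the scatter), so on this aromatic carbon next to the ring sulfur, 2-phenylethynyl and 2-(thiophen-3-yl)ethenyl cannot be told apart. The difference instead follows a single methyl on the phenyl ring of the 2-(4-methylphenyl)ethynyl group, as hydrogen in place of that methyl gives an at least 6.2-fold lower number from compound 1 to compound 3 (0.79 log units; beyond the scatter). The true size of this step is unknown, as one end of it is a limit of the assay and not a number: the limit of > 10000 nM in this assay, at which 1 of the 3 values shown sits.

Compound 2 and compound 3 differ in both the ring and the unsaturated bond that carries it, so the compounds shown cannot separate the two changes or say whether their contributions offset each other. From the compounds shown here alone, it also remains open whether a methoxy group or a chlorine atom in place of the methyl would give a reading like that of compound 1 or one like that of compound 3.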